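From 4-chlorobenzyl to 2-chlorobenzyl: working notes

A few compounds are considered here, and "the series" means these few. Any claim that something is new, unique, unknown or untested is made for them only; others in the source may bear on it.

In a functional assay on GBM2 cells (Homo sapiens) for antiproliferative activity, read by WST assay, with a stated time of 72 h (on this read-out higher numbers stand for weaker inhibition and lower numbers for stronger inhibition), compound 1 `O=C(Nc1cc2ncncc2cc1OCc1ccc(Cl)cc1)Nc1cccc2ccccc12` gives 4500 nM and compound 2 `O=C(Nc1ccc(C(F)(F)F)cc1)Nc1cc2ncncc2cc1OCc1ccccc1` gives 8600 nM. Within the data shown here, these two numbers lie within the scatter of each other, so compound 1 stands level with the only other measured compound.

Compound 3 `O=C(Nc1cc2ncncc2cc1OCc1ccccc1Cl)Nc1cccc2ccccc12` has not yet been measured. Its change from compound 1 is 2-chlorophenyl in place of 4-chlorophenyl on a saturated chain carbon bound to an oxygen on an aromatic ring.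

Among the measured compounds shown here, no measured pair shows what a change of this kind does in this assay, so no step beyond the scatter is expected, in either direction. The expectation is anchored on compound 1 at 4500 nM. The expected change is a 1.1-fold higher number from compound 1 to compound 3 (0.05 log units; within the scatter), an estimate that stays within the scatter. For compound 3, the estimated value is 5000 nM, with an expected range of 2000 nM to 12000 nM.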

Compound 3, half-maximal inhibitory concentration: 2900 nM
Compound 3: the middle estimate sits 1.7-fold (0.24 log units) above what was measured; the range from low to high includes it.
By their numbers in this assay, from the lowest: compounds 3, 1 and 2 (each within the scatter of the next, the first and the last beyond it).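

This gives the series its first step at this position: in this assay, 2-chlorophenyl in place of 4-chlorophenyl on a saturated chain carbon bound to an oxygen on an aromatic ring gives a 1.6-fold lower number from compound 1 to compound 3 (0.19 log units; within the scatter) and so leaves the read-out within the scatter. With the rest of the structure held constant, compound 1 and compound 3 cannot be told apart, so in this pair the read-out does not separate 4-chlorobenzyl from 2-chlorobenzyl. Nothing available bears on why these two groups read alike.

From the compounds shown here alone, what remains open is whether this tolerance extends beyond chlorine, for instance to a methoxy group, an amine or a carboxylic acid in its place on the phenyl ring. Going by these compounds, it is also open whether a longer chain in place of the benzyl carbon would keep the read-out level.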